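The compounds below may be only part of what the source reports. "The series", "measured", "known", "first", "only" and "open" are said of these compounds alone.

Three compounds built on one shared core were tested in a functional assay on the whole organism for inhibition, with Mus musculus as the target, with a stated time of 1 h, at a dose of 100 mg/kg by the intraperitoneal route; on this read-out higher numbers stand for more inhibition at the one dose given (going by the name of the read-out) and lower numbers for less inhibition. Compound 1 `Cc1nc2ccccc2c(=O)n1NC(=O)Nc1ccc(Cl)cc1` gives 48% in this assay. Compound 2 `Cc1ccccc1NC(=O)Nn1c(C)nc2ccccc2c1=O` gives 51%, and compound 3 `Cc1cccc(NC(=O)Nn2c(C)nc3ccccc3c2=O)c1` gives 51%. Compound 3 thus sits within the scatter of both companions: the step of no change at the digits printed from compound 2 to compound 3 (within the scatter) and the step of a number 3 percentage points higher from compound 1 to compound 3 (within the scatter) leave it indistinguishable from either.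

Compound 4 `Cc1ccc(NC(=O)Nn2c(C)nc3ccccc3c2=O)cc1` has not yet been measured. It differs from compound 3 by 4-methylphenyl in place of 3-methylphenyl on an amide-type nitrogen. The three measured steps all concern a change of the aryl group on the same amide-type nitrogen, and all stayed within the scatter: a number 3 percentage points higher from compound 1 to compound 2 (within the scatter), a number 3 percentage points higher from compound 1 to compound 3 (within the scatter) and no change at the digits printed from compound 2 to compound 3 (within the scatter). On that basis no step beyond the scatter is expected for the move from compound 3 to compound 4, in either direction, and the expected step is a number 1 percentage points lower from compound 3 to compound 4 (within the scatter). Compound 4 is therefore estimated to give 50% in this assay, expected to lie between 40% and 60%.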

Compound 4, a percentage reported as inhibition, in the whole organism at one dose (the size of the read-out at that dose, not a potency): 52%
The estimate for compound 4 lay 2 percentage points below the measured number; the measured number falls inside the stated range.
By their numbers in this assay, from the lowest: compounds 1, 2, 3 and 4 (each within the scatter of the next).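

Within this assay, a number 1 percentage points higher from compound 3 to compound 4 (within the scatter) and a number 1 percentage points higher from compound 2 to compound 4 (within the scatter), so the 4-methylphenyl, 3-methylphenyl and 2-methylphenyl groups on the amide-type nitrogen cannot be told apart on this read-out. Compound 4 also adds a matched exchange of chloro for methyl on an aromatic carbon, with a number 4 percentage points higher from compound 1 to compound 4 (within the scatter), and this change too stays within the scatter. Nothing at hand offers an explanation for this flat picture.

Open, going by these compounds, is whether a larger change at this position would separate the compounds, such as an amine or a carboxylic acid on the aromatic ring, or a butyl chain in place of the aryl group on the amide-type nitrogen. Also open, on these data alone, is whether the methyl on the shared core, the same in all four compounds, can be replaced by an ethyl group without moving the number.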